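The source may report more compounds than this note shows. Statements on the series, on what has been measured and on what is new or still open speak of the compounds shown alone.

Series on the shared core of compound 1 `CCCN(CC[C@H]1CC[C@H](NC(=O)/C=C/c2ccc(Cl)cc2)CC1)[C@H]1CCc2nc(N)sc2C1`, varied only at the group on the carbonyl carbon. Among the compounds with values here, in an assay on brain for displacement of a labelled ligand from D(3) dopamine receptor (Rattus norvegicus) (a lower number here means a stronger inhibitor, a higher number a weaker inhibitor), compound 1 gives 2.5 nM, the second highest of the three numbers measured so far. Compound 2 `CCCN(CC[C@H]1CC[C@H](NC(=O)/C=C/c2ccc(OC)cc2)CC1)[C@H]1CCc2nc(N)sc2C1` gives 6.7 nM in this assay; the step of a 2.7-fold higher number from compound 1 to compound 2 (0.43 log units; beyond the scatter) is modest but beyond the scatter. Compound 3 `CCCN(CC[C@H]1CC[C@H](NC(=O)c2ccc(-n3ccnc3)cc2)CC1)[C@H]1CCc2nc(N)sc2C1` gives 1.9 nM; the step of a 1.3-fold lower number from compound 1 to compound 3 (0.12 log units; within the scatter) stays within the scatter, while a 3.5-fold lower number from compound 2 to compound 3 (0.55 log units; beyond the scatter) is modest.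

Compound 4 `CCCN(CC[C@H]1CC[C@H](NC(=O)c2ccc(-n3cccn3)cc2)CC1)[C@H]1CCc2nc(N)sc2C1` is not yet measured. It differs from compound 1 thus: 4-(1H-pyrazol-1-yl)phenyl in place of 2-(4-chlorophenyl)ethenyl on a carbonyl carbon. Within the data shown here, the step bearing on it most closely is the one to compound 3, which also carries 4-(1H-imidazol-1-yl)phenyl on the carbonyl carbon in place of the ethenyl-linked ring; that step, a 1.3-fold lower number from compound 1 to compound 3 (0.12 log units; within the scatter), lay within the scatter. Compound 2 shows only that exchanging methoxy for chloro on an aromatic carbon moves the number modestly. Accordingly the expected step is no change at the digits printed from compound 1 to compound 4 (within the scatter), none beyond the scatter. Compound 4 is estimated at 2.5 nM, with a range from 1 nM to 6.5 nM.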

Compound 4, inhibition constant: 3 nM
Beside the measured number, compound 4's estimate is 1.2-fold (0.08 log units) below it, within the range that was stated.
By their numbers in this assay, from the lowest: compounds 3, 1 and 4 (each within the scatter of the next); then compound 2.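

At the group on the carbonyl carbon, 1H-pyrazol-1-yl in place of 1H-imidazol-1-yl on an aromatic carbon gives a 1.6-fold higher number from compound 3 to compound 4 (0.20 log units; within the scatter) in this assay, so this exchange of the five-membered ring is not resolved here. A second ring-bearing phenyl group thus sits with the 2-(4-chlorophenyl)ethenyl group, at a 1.2-fold higher number from compound 1 to compound 4 (0.08 log units; within the scatter). The step of a 2.2-fold lower number from compound 2 to compound 4 (0.35 log units; beyond the scatter) is modest, and it runs the same way as a 3.5-fold lower number from compound 2 to compound 3 (0.55 log units; beyond the scatter). Nothing measured here accounts for these steps.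

From the compounds shown here alone, what a carboxylic acid or an amine in place of the five-membered ring would do to the number remains open. Also open, going by these compounds, is how these groups read in anything other than this assay.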